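The source may hold more compounds than are shown below. What is called first, only, known or untested is meant among the compounds shown, and "the series" means these compounds.

Among the compounds with values here, in a physicochemical assay for solubility, read by LC-MS, with a stated time of 16 h, at pH 7 (on this read-out higher numbers stand for higher solubility and lower numbers for lower solubility), three compounds sharing one core have numbers so far. Compound 1 `CCCC[S+]([O-])c1sc2nc(-c3nccs3)cc(-c3nccs3)c2c1N` gives 0.3 ug/mL, compound 2 `CCCC[S+]([O-])c1sc2nc(-c3nccs3)cc(-c3ccc(COC(=O)CN(C)C)cc3)c2c1N` gives 6 ug/mL and compound 3 `CCC[S+]([O-])c1sc2nc(-c3nccs3)cc(C)c2c1N` gives 7.7 ug/mL. Compound 2 therefore stands level with compound 3 within the scatter, and clearly higher than compound 1. Compound 4 `CCCC[S+]([O-])c1sc2nc(-c3nccs3)cc(-c3ccc(CNC(C)=O)cc3)c2c1N` differs from compound 2 by acetamido in place of (((dimethylamino)methyl)carbonyl)oxy on a saturated chain carbon bound to an aromatic carbon. Within the data shown here, no measured pair shows this change alone, so the expectation stays loose. A moderate fall is expected in this assay, an estimated 3.0-fold lower number from compound 2 to compound 4 (0.48 log units; beyond the scatter). Among the measured compounds shown here, the only low number known, from compound 1 at 0.3 ug/mL, sets the lower reach of that expectation. For compound 4 the estimated value is 2 ug/mL, with an expected range of 0.5 ug/mL to 7 ug/mL.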

Compound 4, solubility: 2.16 ug/mL
Compound 4: middle estimate off by 1.1-fold (0.03 log units), on the low side; the measured number falls inside the stated range.
By their numbers in this assay, from the lowest: compound 1; then compound 4; then compounds 2 and 3 (each within the scatter of the next).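

In this assay, within the data shown here, acetamido in place of (((dimethylamino)methyl)carbonyl)oxy on a saturated chain carbon bound to an aromatic carbon gives a 2.8-fold lower number from compound 2 to compound 4 (0.44 log units; beyond the scatter), the first change here that can be read alone. Among these compounds, the step is modest, yet it shows that this position responds to the group it carries, which the earlier compounds, differing in more than one place, could not show. Nothing available explains the step. From the compounds shown here alone, what an amine without the ester, a carboxylic acid or a longer amide chain would give on this carbon stays open. So does whether the step would hold with other groups elsewhere on the shared core.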